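The compounds below may be only part of what the source reports. "The series", "measured", "known", "first", "only" and "open" are said of these compounds alone.

The measured compounds:
Compound 1 `CCc1nnc(NC(=O)Cn2c(-c3ccccc3)cc(-c3ccccc3)c2-c2ccco2)s1`, which in an ADME assay on HEK-293T cells (Homo sapiens) for cytotoxicity, read by MTT assay, with a stated time of 72 h (on this read-out lower numbers stand for stronger inhibition and higher numbers for weaker inhibition), gives < 50000 nM, a limit of the assay rather than a number.
Compound 2 `O=C(Cn1c(-c2ccccc2)cc(-c2ccco2)c1-c1ccco1)Nc1nc2ccccc2s1`, which in this assay gives < 50000 nM, again a limit rather than a number.

Compound 2 thus stands at the limit, and so does the other value shown: the limit of < 50000 nM in this assay, at which 2 of the 2 values shown sit. Going by the values given here, with both values at the limit, no step between measured compounds can be read, and the two values show only that neither compound reached the read-out within the range tested.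

Compound 3 `CCc1nnc(NC(=O)Cn2c(-c3ccccc3)cc(-c3ccco3)c2-c2ccco2)s1` differs from compound 2 by 5-ethyl-1,3,4-thiadiazol-2-yl in place of 1,3-benzothiazol-2-yl on an amide-type nitrogen. Compound 1 already carries the 5-ethyl-1,3,4-thiadiazol-2-yl group on the same kind of nitrogen, and its value is likewise a limit. The step that the limit leaves unreadable from compound 2 to compound 3 is therefore expected to be none beyond the scatter, with the result most likely reported once more as a limit. Compound 3 is expected to give 35000 nM, in the range 10000 nM to 50000 nM.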

Compound 3, half-maximal inhibitory concentration: < 50000 nM
Compound 3: a limit, no number; the forecaster's own chance of this, stated with the estimate: 80%; the middle value lies beyond the limit too.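

Compound 3 also gives a limit rather than a number, so no step can be read from compound 2 to compound 3 or from compound 1 to compound 3, and all three compounds share one limit: the limit of < 50000 nM in this assay, at which 3 of the 3 values shown sit. The compounds shown leave open where their actual values lie in this assay and whether either change alters them.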